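The source may hold more compounds than are shown below. What is called first, only, known or untested is meant among the compounds shown, and "the series" means these compounds.

Measured in a functional assay on B16-F0 cells (Mus musculus) for inhibition, read by CCK-8 assay, with a stated time of 48 h; on this read-out lower numbers stand for stronger inhibition and higher numbers for weaker inhibition:
- compound 1 `COc1cc(-c2ccnc3cc(-c4ccc(F)cc4)nn23)cc(OC)c1OC`: 4540 nM
- compound 2 `COc1cc(-c2cc3nccc(-c4c[nH]c5ccccc45)n3n2)cc(OC)c1OC`: > 10000 nM (a limit of the assay, not a number)

Going by the values given here, compound 1 gives the only actual number, 4540 nM. The entry for compound 2 is only a limit.

Compound 3 `COc1cc(-c2ccnc3cc(-c4c[nH]c5ccccc45)nn23)cc(OC)c1OC` differs from compound 1 in one place, with 1H-indol-3-yl in place of 4-fluorophenyl on an aromatic carbon. Among the compounds with values here, no measured step covers this swap, so the expectation is loose: a moderate gain in this assay, towards stronger inhibition. The expected change is a 4.5-fold lower number from compound 1 to compound 3 (0.66 log units; beyond the scatter). For compound 3 the estimated value is 1000 nM, within an expected range of 80 nM to 8000 nM.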

Compound 3, half-maximal inhibitory concentration: 40 nM
Estimate against measurement, compound 3: 25-fold (1.40 log units) above, outside the stated range (below it).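

In this assay, the position on the five-membered aromatic ring with 2 nitrogen turns out to be highly sensitive: 1H-indol-3-yl in place of 4-fluorophenyl gives a 110-fold lower number from compound 1 to compound 3 (2.05 log units; beyond the scatter), a large step. Until now compound 1 held the only actual number, so nothing had shown how much the group here could matter. Nothing measured here accounts for the size of this step.

Still open, going by these compounds, is whether the indole's hydrogen-bond donor or its second ring carries the gain. On these data alone, how an amine or a carboxylic acid would read at this position also remains unknown.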